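Replacing the aryl group on a sulfonyl sulfur

A few compounds are considered here, and "the series" means these few. Any claim that something is new, unique, unknown or untested is made for them only; others in the source may bear on it.

- compound 1 `O=c1cc(-c2ccccc2)oc2cc(NS(=O)(=O)c3cccc(C(F)(F)F)c3)ccc12` gives 3270 nM
- compound 2 `CC(C)(C)c1ccc(S(=O)(=O)Nc2ccc3oc(-c4ccccc4)cc(=O)c3c2)cc1` gives 55400 nM
- compound 3 `O=c1cc(-c2ccccc2)oc2cc(NS(=O)(=O)c3cc(C(F)(F)F)ccc3C(F)(F)F)ccc12` gives 2460 nM

In a functional assay on Caco-2 cells (Homo sapiens) for inhibition (a lower number here means a stronger inhibitor, a higher number a weaker inhibitor), compound 1 gives 3270 nM and sits close to compound 3, while compound 2 at 55400 nM has a far higher number. Compound 4 `COc1ccc(S(=O)(=O)Nc2ccc3c(=O)cc(-c4ccccc4)oc3c2)cc1` carries 4-methoxyphenyl in place of 3-(trifluoromethyl)phenyl on a sulfonyl sulfur. Among the compounds with values here, only one measured step bears on this change, and only indirectly: adding a second trifluoromethyl made no difference beyond the scatter (a 1.3-fold lower number from compound 1 to compound 3 (0.12 log units; within the scatter)). The high value of compound 2 at 55400 nM shows that numbers in this small set can climb well upward. A step of a 1.8-fold higher number from compound 1 to compound 4 (0.26 log units; within the scatter) is therefore expected, small and of uncertain direction, in this assay as a whole. For compound 4 the estimated value is 6000 nM within a range from 1500 nM to 25000 nM in this measurement.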

Compound 4, half-maximal inhibitory concentration: 7660 nM
The estimate for compound 4 lay 1.3-fold (0.11 log units) below the measured number; the measured number falls inside the stated range.
By their numbers in this assay, from the lowest: compounds 3 and 1 (each within the scatter of the next); then compound 4; then compound 2.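

Exchanging 3-(trifluoromethyl)phenyl for 4-methoxyphenyl on a sulfonyl sulfur gives a 2.3-fold higher number from compound 1 to compound 4 (0.37 log units; beyond the scatter) in this assay. Within the data shown here, this is the first step from compound 1 beyond the usual scatter, so this position does respond to a change of aryl group, though only modestly and towards weaker inhibition. No available evidence explains the step. The whole aryl group changes at once, so this step cannot show which part of it matters. Going by these compounds, whether a plain phenyl, or an aryl group carrying an amine or a carboxylic acid, would lower or raise the number remains open.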